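A Methoxyphenoxy Variant Built on a Measured Methoxyphenyl

The source may report more compounds than this note shows. Statements on the series, on what has been measured and on what is new or still open speak of the compounds shown alone.

Of the compounds shown here, two have been measured in an assay on isolated protein for agonist activity at Bile acid receptor (Homo sapiens), read by AlphaScreen, with a stated time of 30 min; on this read-out lower numbers stand for an effect already at smaller amounts and higher numbers for an effect only at larger amounts of compound. Compound 1 `Cc1ccccc1-n1nc(C)c2c1NC(=O)[C@H](C)S[C@@H]2c1ccc(-c2cc3ccccc3o2)cc1` gives 1500 nM. Compound 2 `COc1ccccc1-c1ccc([C@H]2S[C@@H](C)C(=O)Nc3c2c(C)nn3-c2ccccc2C)cc1` gives 1100 nM in this assay, the smaller of the two numbers shown, though the gap to compound 1 lies within the scatter. Among the measured compounds shown here, the one measured step, a 1.4-fold lower number from compound 1 to compound 2 (0.13 log units; within the scatter), is within the scatter and therefore shows no real effect of swapping the group on that aromatic carbon. Compound 3 `COc1ccc(Oc2ccc([C@H]3S[C@@H](C)C(=O)Nc4c3c(C)nn4-c3ccccc3C)cc2)cc1` differs from compound 2 by one change: 4-methoxyphenoxy in place of 2-methoxyphenyl on an aromatic carbon. For the measured compounds named here, the only step that bears on this position is a 1.4-fold lower number from compound 1 to compound 2 (0.13 log units; within the scatter), and it was small. On that basis no step beyond the scatter is expected in this assay for compound 3. Compound 3 is estimated to give 1300 nM, with a range from 400 nM to 4000 nM. The expected step is therefore a 1.2-fold higher number from compound 2 to compound 3 (0.07 log units; within the scatter).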

Compound 3, half-maximal effective concentration: 2200 nM
Estimate against measurement, compound 3: 1.7-fold (0.23 log units) below; measured number inside the range.
By their numbers in this assay, from the lowest: compounds 2, 1 and 3 (each within the scatter of the next).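

Compound 3 adds a third kind of group on this aromatic carbon, and in this assay the steps are a 2.0-fold higher number from compound 2 to compound 3 (0.30 log units; within the scatter) and a 1.5-fold higher number from compound 1 to compound 3 (0.17 log units; within the scatter). Among the compounds shown here, the earlier pair had compared only two directly attached aromatic groups, whereas these steps extend the comparison to the oxygen-linked 4-methoxyphenoxy, and all three compounds remain within the scatter of one another, so the series shows no measurable preference among 1-benzofuran-2-yl, 2-methoxyphenyl and 4-methoxyphenoxy at this place. No measured information is available to explain these results.

All three groups are uncharged and each carries an aromatic ring, so the compounds shown do not tell whether this position would respond differently to a carboxylic acid or an amine. They also leave open whether a step beyond the scatter can be obtained here at all.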